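The source may report more compounds than this note shows. Statements on the series, on what has been measured and on what is new or still open speak of the compounds shown alone.

Measured compounds:

Compound 1, `N=C(N)N/N=C/c1c(-c2ccncc2)nc2sc(Cl)cn12`, in a functional assay (Homo sapiens) for antiproliferative activity (a higher number here means a weaker inhibitor of growth, a lower number a stronger inhibitor of growth), gives 40700 nM.
Compound 2, `Cc1sc2nc(-c3ccncc3)c(/C=N/NC(=N)N)n2c1C`, in this assay gives 91200 nM.
Compound 3, `Cc1cn2c(/C=N/NC(=N)N)c(-c3ccccn3)nc2s1`, in this assay gives 37200 nM.

All three numbers are high, so none of these compounds is a strong inhibitor of growth. Compound 3 has the lowest number of the three, but its gap to compound 1 lies within the scatter, so the two cannot be told apart; only compound 2 stands clearly apart from compound 3, with a higher number that lies beyond the scatter.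

Compound 4, `Cc1cn2c(/C=N/NC(=N)N)c(-c3ccncc3)nc2s1`, has not yet been measured. It keeps every atom of compound 3 but joins them differently: pyridin-4-yl in place of pyridin-2-yl on an aromatic carbon. Among the measured compounds shown here, no pair of measured compounds differs in this one place alone, so the size of this step is not known from the data. Compound 1 and compound 2, which both carry a pyridin-4-yl, sit on either side of compound 3 in this assay, one within the scatter and one beyond it. The expected step is therefore small, toward a somewhat higher number, and may not exceed the scatter: an estimated 1.5-fold higher number from compound 3 to compound 4 (0.17 log units; within the scatter). Compound 4 is thus expected to give about 55000 nM in this assay, with a likely range from 20000 nM to 150000 nM.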

Compound 4, concentration for total growth inhibition: 47900 nM
The estimate for compound 4 lay 1.1-fold (0.06 log units) above the measured number; low and high end bracket the measured number.
By their numbers in this assay, from the lowest: compounds 3, 1, 4 and 2 (each within the scatter of the next, the first and the last beyond it).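

Placing pyridin-4-yl in place of pyridin-2-yl, on the aromatic carbon next to the ring nitrogen, gives a 1.3-fold higher number from compound 3 to compound 4 (0.11 log units; within the scatter) in this assay, so this is the first direct reading of this change, and the two compounds cannot be told apart. Among the compounds shown here, compound 4 also provides the first single-place readings for the other substituted ring carbons: hydrogen in place of methyl gives a 1.9-fold lower number from compound 2 to compound 4 (0.28 log units; within the scatter), and methyl in place of chloro gives a 1.2-fold higher number from compound 1 to compound 4 (0.07 log units; within the scatter), so neither swap shows a clear effect, and all three single changes stay within the scatter. No further measurement bears on these results, so what lies behind them cannot be said from the data shown.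

On these data alone, whether a phenyl or pyridin-3-yl group at the position of the pyridine ring, or an amine or a longer chain in place of the methyl, would move the number beyond the scatter remains open. Every number shown is high, so these compounds also leave open which single change, if any, could produce a strong inhibitor of growth.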